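Compound 3 to compound 4: nitro in place of chloro

This account rests on a few compounds, and the source may have more. Where it says the series, first, only, none or still open, it means among the compounds named here.

In an ADME assay on MRC5 cells (Homo sapiens) for cytotoxicity, read by neutral red uptake (a higher number here means that more compound is tolerated, a lower number that less compound is tolerated), compound 3 (`O=c1[nH]c(SCc2ccccc2Cl)nc2ccccc12`) gives > 65000 nM as a limit of the assay, not a number. Compound 1 (`O=c1[nH]c(SCc2ccc(-c3ccccc3)cc2)nc2ccccc12`) gives > 64000 nM as a limit too. Compound 2 (`COc1ccc(CSc2nc3ccccc3c(=O)[nH]2)cc1`) gives > 64000 nM as a limit as well. Compounds 1 and 2 thus share the limit of > 64000 nM in this assay, at which 2 of the 3 values shown sit, as their reading. Among the measured compounds shown here, compound 3 stands alone at the limit of > 65000 nM in this assay, at which 1 of the 3 values shown sits, as its reading, so no compound so far has a numerical value.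

Compound 4 (`O=c1[nH]c(SCc2ccccc2[N+](=O)[O-])nc2ccccc12`) carries nitro in place of chloro on an aromatic carbon, ortho to a large group: nitro in place of chloro on an aromatic carbon is the counted change.

For the measured compounds named here, only one measured step exists, a step that the two limits leave unreadable from compound 1 to compound 2 for methoxy in place of phenyl on an aromatic carbon. Its size cannot be read, and it does not involve the nitro or chloro group. Going by the values given here, it therefore offers no size to carry over, and the only anchor is compound 3 at > 65000 nM as a limit. No step beyond the scatter is expected in this assay in either direction. The expected change is an at least 1.0-fold lower number from compound 3 to compound 4 (0.03 log units; that floor lies within the scatter) as an estimate. Compound 4 is estimated at 60000 nM, with the expected range running from 25000 nM to 70000 nM as its span.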

Compound 4, half-maximal cytotoxic concentration: > 64000 nM
Compound 4: no number, only a limit; the forecaster's own chance of this, stated with the estimate: 70%; at least 1.0-fold (0.02 log units) between middle value and limit.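

Among the compounds shown here, compound 3 and compound 4 both give limits of the assay in this assay, not numbers, and no step between them can be read. None of the four compounds shown has a numerical value, which leaves open where any of them reaches its half-maximal cytotoxic concentration and whether nitro in place of chloro changes it.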